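From compound 2 to compound 4: working notes

The source may report more compounds than this note shows. Statements on the series, on what has been measured and on what is new or still open speak of the compounds shown alone.

Measured so far in a functional assay on NCI-H460 cells (Homo sapiens) for inhibition, with a stated time of 48 h; a lower number here means a stronger inhibitor of growth, a higher number a weaker inhibitor of growth

Compound 1 `N#Cc1cnn(-c2ccc(C(=O)O)cc2)c1N` gives "not determined" (no result reported)
Compound 2 `COC(=O)CNC(=O)c1ccc(-n2ncc3c(N)ncnc32)cc1` gives > 150000 nM
Compound 3 `CC(=O)OC[C@H]1O[C@@H](Nc2ncnc3c2cnn3-c2ccc(C(=O)O)cc2)[C@H](OC(C)=O)[C@@H](OC(C)=O)[C@@H]1OC(C)=O` gives > 150000 nM

In this assay, going by the values given here, compound 2 gives > 150000 nM as a limit, not a number, so there is no measured figure to step from. Compound 3 likewise gives > 150000 nM as a limit. Compound 1 carries no result. The series thus offers only the limit of > 150000 nM in this assay, at which 2 of the 3 values shown sit, as a reference point.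

The change to compound 4 `COc1ccc(-n2ncc3c(N)ncnc32)cc1` is methoxy in place of ((methoxycarbonyl)methyl)carbamoyl on an aromatic carbon and puts methoxy in place of ((methoxycarbonyl)methyl)carbamoyl on an aromatic carbon. Among the compounds with values here, no measured step gives a size for this change. A small move toward stronger inhibition of growth is expected, starting from the limit of > 150000 nM in this assay, at which 2 of the 3 values shown sit, and staying close to it. The expected change in this assay is an at least 1.6-fold lower number from compound 2 to compound 4 (0.22 log units; that floor lies within the scatter) as an estimate only. A report of only a limit is expected about as often as a number. The estimate for compound 4 is 90000 nM with an expected range from 25000 nM to 150000 nM in this series.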

Compound 4, concentration for 50% growth inhibition: > 150000 nM
Compound 4 was reported as a limit (the forecaster's own chance of this, stated with the estimate: 55%); at least 1.6-fold (0.22 log units) between middle value and limit.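

In this assay compound 4 gives > 150000 nM, which is a limit and not a number. Compound 2 also stands only as a limit, so no step can be read between compound 2 and compound 4. The compounds shown leave open whether methoxy in place of ((methoxycarbonyl)methyl)carbamoyl changes growth inhibition at all.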